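Ethoxycarbonyl to carboxy: the step to compound 4

The source may report more compounds than this note shows. Statements on the series, on what has been measured and on what is new or still open speak of the compounds shown alone.

In a functional assay on HepG2 cells (Homo sapiens) for antiproliferative activity, read by MTT assay, with a stated time of 48 h (a lower number here means a stronger inhibitor, a higher number a weaker inhibitor), compound 1 (`C=CCN(C)C(=O)c1ccc(C(CC)(CC)c2ccc(OCCC(O)(CC)CC)c(C)c2)n1CC`) gives > 50000 nM, a limit of the assay and not a number. Compound 2 (`CCn1c(C(=O)Nc2cccc(C(F)(F)F)c2)ccc1C(CC)(CC)c1ccc(OCCC(O)(CC)CC)c(C)c1`) gives > 50000 nM, likewise a limit. Going by the values given here, compound 3 (`CCOC(=O)CN(C)C(=O)c1ccc(C(CC)(CC)c2ccc(OCCC(O)(CC)CC)c(C)c2)n1CC`) gives 25300 nM, the only actual number so far. The remaining picture is the limit of > 50000 nM in this assay, at which 2 of the 3 values shown sit.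

Compound 4 (`CCn1c(C(=O)N(C)CC(=O)O)ccc1C(CC)(CC)c1ccc(OCCC(O)(CC)CC)c(C)c1`) has not yet been measured. Its difference from compound 3 is hydrogen in place of ethyl on an oxygen next to a carbonyl group. In short, ethoxycarbonyl becomes carboxy.

Among the compounds with values here, no measured step makes this exact change. The nearest are an at least 1.9-fold lower number from compound 1 to compound 3 (0.29 log units; that floor lies within the scatter) and an at least 1.9-fold lower number from compound 2 to compound 3 (0.29 log units; that floor lies within the scatter). Within the data shown here, both end at compound 3, the one compound carrying ethoxycarbonyl, but both are only floors within the scatter, so their support is weak.

Among the measured compounds shown here, the expectation rests on compound 3, whose 25300 nM is the only number available: with ethoxycarbonyl gone, a move towards a higher number in this assay is expected. For compound 4 there is a real chance that this assay reports only a limit. The expected step is a 1.8-fold higher number from compound 3 to compound 4 (0.25 log units; within the scatter). For compound 4 the estimate is 45000 nM, with an expected range of 22000 nM to 90000 nM.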

Compound 4, half-maximal inhibitory concentration: 5710 nM
The estimate for compound 4 lay 7.9-fold (0.90 log units) above the measured number; the whole stated range lies above it.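

In this assay, going by these compounds alone, the change of ethoxycarbonyl to carboxy gives a 4.4-fold lower number from compound 3 to compound 4 (0.65 log units; beyond the scatter), the first step read from two actual numbers and the first of that kind to lie beyond the scatter, so the ethyl on this oxygen is not required for activity and its loss moves the number down. Against the other groups on the amide carbonyl, the carboxymethyl compound also clears the scatter, with an at least 8.7-fold lower number from compound 2 to compound 4 (0.94 log units; beyond the scatter) and an at least 8.7-fold lower number from compound 1 to compound 4 (0.94 log units; beyond the scatter), whereas the floors ending at compound 3 stayed within it. These two steps are floors and not sizes because compound 1 and compound 2 each stand at a limit of the assay, not at a number: the limit of > 50000 nM in this assay, at which 2 of the 4 values shown sit.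

Open, going by these compounds, is whether the free carboxylic acid itself is what counts at this place, or whether a primary amide, a tetrazole or a methyl ester on the same chain would read the same way. Also open, on these data alone, are the effect of a longer chain between the amide nitrogen and the carboxy group, such as carboxyethyl, and whether the methyl on that nitrogen can be replaced by hydrogen.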